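A few compounds are considered here, and "the series" means these few. Any claim that something is new, unique, unknown or untested is made for them only; others in the source may bear on it.

Compound 1, `COc1cc2c(Oc3ccc(NC(=O)c4cn(-c5ccc(F)c(F)c5)nn4)cc3F)ccnc2cc1OCCCN1CCC(C)CC1`, gives 260 nM in a functional assay on NCI-H460 cells (Homo sapiens) for cytotoxicity, read by MTT assay, with a stated time of 72 h; a lower number here means a stronger inhibitor, a higher number a weaker inhibitor.
Compound 2, `COc1cc2c(Oc3ccc(NC(=O)c4cn(-c5ccccc5F)nn4)cc3F)ccnc2cc1OCCCN1CCN(C)CC1`, gives 230 nM.
Compound 3, `COc1cc2c(Oc3ccc(NC(=O)c4cn(-c5c(C)cccc5C)nn4)cc3F)ccnc2cc1OCCCN1CCN(C)CC1`, gives 4540 nM.

Compound 3 stands at the top of the three numbers, well apart from both other compounds; its gap to compound 1 is the smaller one and its gap to compound 2 the larger, and each of them lies beyond the usual scatter. For the measured compounds named here, the one single-point step among the measured compounds is a 20-fold higher number from compound 2 to compound 3 (1.30 log units; beyond the scatter), a large loss that comes with nothing more than the exchange of the aryl group on the aromatic nitrogen.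

Compound 4, `COc1cc2c(Oc3ccc(NC(=O)c4cn(-c5ccc(F)c(F)c5)nn4)cc3F)ccnc2cc1OCCCN1CCN(C)CC1`, differs from compound 3 in the same place: 3,4-difluorophenyl in place of 2,6-dimethylphenyl on an aromatic nitrogen. This change undoes the aryl exchange of the measured step, and the whole of the rest of the molecule is that of compound 2. Compound 1, which already carries the 3,4-difluorophenyl group on a core that differs only in the basic amine at the end of the chain, gives 260 nM, close to compound 2. The step is therefore expected to be a large one in the opposite direction, an 18-fold lower number from compound 3 to compound 4 (1.26 log units; beyond the scatter), back into the range of compound 1 and compound 2. Compound 4 is estimated at 250 nM, within 110 nM to 600 nM.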

Compound 4, half-maximal inhibitory concentration: 250 nM
Beside the measured number, compound 4's estimate shows no gap at the digits printed; the measured number falls inside the stated range.
By their numbers in this assay, from the lowest: compounds 2, 4 and 1 (each within the scatter of the next); then compound 3.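

In this assay, putting 3,4-difluorophenyl on the aromatic nitrogen in place of 2,6-dimethylphenyl is a large gain (an 18-fold lower number from compound 3 to compound 4 (1.26 log units; beyond the scatter)), so the poor number of compound 3 belongs to that aryl group and not to the rest of the molecule, even though the two groups match in their counts of heavy atoms, donors and acceptors. The position accepts both fluorinated aryl groups shown, with 3,4-difluorophenyl and 2-fluorophenyl lying within the scatter of each other (a 1.1-fold higher number from compound 2 to compound 4 (0.04 log units; within the scatter)), and the far end of the chain accepts both amines, with 4-methylpiperazin-1-yl and 4-methylpiperidin-1-yl also within the scatter (a 1.0-fold lower number from compound 1 to compound 4 (0.02 log units; within the scatter)). No measurement at hand bears on what lies behind the large step or the two flat ones.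

The compounds shown leave open whether the loss in compound 3 goes with the methyl groups themselves or with their placement, which 2-methylphenyl, 4-methylphenyl or 2,6-difluorophenyl on the aromatic nitrogen would help to separate. They also leave open how far the chain end can vary, for instance with a morpholine or a dimethylamino group.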